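This account rests on a few compounds, and the source may have more. Where it says the series, first, only, none or still open, it means among the compounds named here.

Of the compounds shown here, three have so far been measured in an assay on CHO-TREX cells for antagonist activity at transient receptor potential cation channel subfamily A member 1 (Homo sapiens), read by FLIPR and calcium flux, with a stated time of 10 min; a lower number here means a stronger inhibitor, a higher number a weaker inhibitor. Compound 1 `FC(F)(F)Oc1ccccc1-c1ccc2[nH]ncc2c1` gives 3430 nM in this assay. Compound 2 `N#Cc1ccccc1-c1ccc2[nH]ncc2c1` differs from compound 1 by one change, (cyano in place of trifluoromethoxy on an aromatic carbon), and in this assay compound 2 gives 1290 nM. That change produced a step of a 2.7-fold lower number from compound 1 to compound 2 (0.42 log units; beyond the scatter). Compound 3 `FC(F)(F)Oc1cc2[nH]ncc2cc1-c1ccccc1C(F)(F)F` is built on a different core; how its core differs from the core of compound 1 is not broken down here. In this assay compound 3 gives 36 nM, the lowest of the three numbers.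

Compound 4 `N#Cc1cc2[nH]ncc2cc1-c1ccccc1C(F)(F)F` has not yet been measured. It differs from compound 3 by cyano in place of trifluoromethoxy on an aromatic carbon. Among the compounds with values here, this is the same kind of change as the one from compound 1 to compound 2, not the same change: in compound 2 the cyano sits on a six-membered aromatic ring of carbon only, ortho to a group of 9 heavy atoms, whereas in compound 4 it sits on a ring that is part of a fused or bridged system of two rings, ortho to a large group, meta to a fused ring and para to a fused ring. Within the data shown here, the step from compound 3 to compound 4 in this assay is expected to be a 1.8-fold lower number from compound 3 to compound 4 (0.26 log units; within the scatter), somewhat smaller than the earlier step, as the surroundings of the change differ and only one example of it is available. Compound 4 is therefore estimated at 20 nM, with a likely range from 5 nM to 80 nM.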

Compound 4, half-maximal inhibitory concentration: 129 nM
Compound 4: middle estimate off by 6.5-fold (0.81 log units), on the low side; the whole stated range lies below it.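

In this assay, putting cyano in place of trifluoromethoxy on the core of compound 3 gave a 3.6-fold higher number from compound 3 to compound 4 (0.55 log units; beyond the scatter) and so weakened the inhibitor, whereas the same swap on the core of compound 1 had strengthened it. The two steps run in opposite directions, and the gap between them is larger than scatter alone would explain: the same change on two cores in this assay, a 2.7-fold lower number (0.42 log units; beyond the scatter) from compound 1 to compound 2 and a 3.6-fold higher number (0.55 log units; beyond the scatter) from compound 3 to compound 4, 9.5-fold (0.98 log units) apart, beyond the scatter of two such steps. This shows that the effect of this change cannot simply be carried from one core to the other in this series, but it does not show why, since the two pairs differ in more than one way, including the ring that carries the change, and two pairs cannot predict the result on a further core.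

The compounds shown hold only cyano or trifluoromethoxy at this place, so it remains open how an amine, a carboxylic acid or a longer chain there would compare. Going by these compounds, it is also open whether the gain from cyano on the core of compound 1 would return with a methoxy group in place of the trifluoromethyl group of compound 4.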